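From 2-aminophenyl to anilino: an unmeasured step

The source may hold more compounds than are shown below. What is called first, only, known or untested is meant among the compounds shown, and "the series" means these compounds.

- compound 1 `Nc1ccccc1/N=C\c1cc(=O)oc2cc(OCc3ccccc3)cc(OCc3ccccc3)c12`: 7530 nM
- compound 2 `Nc1ccccc1/N=C\c1cc(=O)oc2cc(OCc3ccccc3)ccc12`: 9250 nM
- compound 3 `O=c1cc(/C=N\Nc2ccc([N+](=O)[O-])cc2[N+](=O)[O-])c2ccc(OCc3ccccc3)cc2o1`: 6490 nM

These values come from a functional assay, read by spectrophotometry, with a stated time of 3 min; a higher number here means a weaker inhibitor, a lower number a stronger inhibitor. The value of compound 1 lies within the scatter of both neighbouring values, so no ranking can be read from these numbers.

The next compound, compound 4 `O=c1cc(/C=N\Nc2ccccc2)c2c(OCc3ccccc3)cc(OCc3ccccc3)cc2o1`, keeps the same atoms but joins them differently: anilino in place of 2-aminophenyl on a double-bonded nitrogen. Going by the values given here, no measured step makes exactly this change. Among the compounds with values here, the one measured step, a 1.2-fold higher number from compound 1 to compound 2 (0.09 log units; within the scatter), concerns a different change, hydrogen in place of benzyloxy on an aromatic carbon, and it stays within the scatter. Compound 3 also carries a substituted anilino group at that place, though it differs elsewhere too, and its 6490 nM lies close to the value of compound 1. On this thin evidence, the expected change is a 1.1-fold lower number from compound 1 to compound 4 (0.03 log units; within the scatter), which means no shift beyond the scatter in either direction. Compound 4 is estimated at 7000 nM, with an expected range from 3000 nM to 15000 nM.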

Compound 4, half-maximal inhibitory concentration: 40100 nM
Beside the measured number, compound 4's estimate is 5.7-fold (0.76 log units) below it; measured number above the stated range.
By their numbers in this assay, from the lowest: compounds 3, 1 and 2 (each within the scatter of the next); then compound 4.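

Going by these compounds alone, at this position, on a double-bonded nitrogen, the change to anilino from 2-aminophenyl gives in this assay a step beyond the scatter, a 5.3-fold higher number from compound 1 to compound 4 (0.73 log units; beyond the scatter), whereas the only earlier step, the loss of a benzyloxy group, stayed within it. The two groups have the same counts of heavy atoms, hydrogen-bond donors and acceptors and no net charge, so these counts alone do not predict the result: the way the same atoms are joined matters here. Nothing available explains why the number rises.

On these data alone, it remains open whether a plain phenyl group or a 2-hydroxyphenyl group at this place would give a number like that of compound 1 or like that of compound 4. The compounds shown also leave open whether this step would be the same size on a core with a single benzyloxy group.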